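Swapping a dihalogenated ring for a bromophenyl on the chain

This account rests on a few compounds, and the source may have more. Where it says the series, first, only, none or still open, it means among the compounds named here.

Among the compounds with values here, compound 1, `O=C(COc1ccc(C(=O)/C=C/c2ccc(F)c(F)c2)cc1)N[C@H]1CCOC1=O`, is the only member of this small set that gives an actual number. In a functional assay on DU-145 cells (Homo sapiens) for antiproliferative activity, read by MTT assay, with a stated time of 72 h (on this read-out higher numbers stand for weaker inhibition and lower numbers for stronger inhibition), compound 1 gives 19800 nM. Compound 2, `CC(C)c1ccc(NCC(=O)N[C@H]2CCOC2=O)cc1`, reaches only a limit of the assay, and in this assay compound 2 gives > 64000 nM. Compound 3, `Cc1cc(Cl)ccc1NCC(=O)N[C@H]1CCOC1=O`, likewise reaches only a limit, and in this assay compound 3 gives > 64000 nM. Two of the three results therefore sit at the limit of > 64000 nM in this assay, at which 2 of the 3 values shown sit, so compound 1 stands alone as the one measurable inhibitor.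

Compound 4, `O=C(COc1ccc(C(=O)/C=C/c2cccc(Br)c2)cc1)N[C@H]1CCOC1=O`, keeps the whole of compound 1 apart from one ring on the chain: 3-bromophenyl in place of 3,4-difluorophenyl on a double-bonded chain carbon bound to a double-bonded chain carbon. Within the data shown here, no measured pair in this set differs in a single place, so there is no step from which to read the likely size of this change. With two halogens leaving and one bromine entering on the same aromatic ring, the expectation is a step no larger than the usual scatter, in either direction, with the estimated step from compound 1 to compound 4 being a 1.2-fold lower number from compound 1 to compound 4 (0.09 log units; within the scatter). Compound 4 is accordingly expected to give about 16000 nM in this assay, with a plausible range from 5000 nM to 50000 nM.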

Compound 4, half-maximal inhibitory concentration: 9800 nM
Compound 4: the middle estimate sits 1.6-fold (0.21 log units) above what was measured; the measured number falls inside the stated range.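

In this assay, within the data shown here, replacing 3,4-difluorophenyl with 3-bromophenyl gives a 2.0-fold lower number from compound 1 to compound 4 (0.31 log units; beyond the scatter), the first step in this set that can be read at all. It shows that the ring on a double-bonded chain carbon bound to a double-bonded chain carbon is a place where the number can move, although this one change moves it only modestly, and that the shared core tolerates the bromine-bearing ring with somewhat stronger inhibition. Nothing measured here tells why the number moved.

This single step cannot separate the effect of adding bromine from that of removing the two fluorines, so a phenyl ring with one fluorine or one chlorine would be the informative next comparison. On these data alone, what a ring carrying a methoxy group, an amine or a carboxylic acid would give at this place also remains open.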